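Branching the Amide Chain of an Alpha-Ketoamide Inhibitor

The source may report more compounds than this note shows. Statements on the series, on what has been measured and on what is new or still open speak of the compounds shown alone.

Measured compounds: compound 1 `CCCCOC(=O)C(=O)C(CC)NC(=O)C(CC(C)C)NC(=O)OCc1ccccc1`, 28000 nM; compound 2 `CCCCNC(=O)C(=O)C(CC)NC(=O)C(CC(C)C)NC(=O)OCc1ccccc1`, 35000 nM.

In a functional assay for inhibition, with Rattus norvegicus as the target, at pH 7.35 (a lower number here means a stronger inhibitor, a higher number a weaker inhibitor), compound 1 gives 28000 nM and compound 2 gives 35000 nM. Compound 2 stands beside compound 1, since the step of a 1.3-fold higher number from compound 1 to compound 2 (0.10 log units; within the scatter) does not leave the scatter. Compound 3 `CCC(NC(=O)C(CC(C)C)NC(=O)OCc1ccccc1)C(=O)C(=O)NCC(C)C` differs from compound 2 by isopropyl in place of propyl on a saturated chain carbon bound to an amide-type nitrogen. Among the compounds with values here, no measured step bears on that change; the only measured step, a 1.3-fold higher number from compound 1 to compound 2 (0.10 log units; within the scatter), touched another place. So compound 3 is expected to show no step beyond the scatter, no change at the digits printed from compound 2 to compound 3 (within the scatter), and its estimate is 35000 nM, within 12000 nM to 100000 nM.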

Compound 3, half-maximal inhibitory concentration: 28000 nM
For compound 3 the middle estimate is 1.3-fold (0.10 log units) above the measured one, within the range that was stated.
By their numbers in this assay, from the lowest: compounds 1, 3 and 2 (each within the scatter of the next).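

In this assay, the branched chain gives a 1.3-fold lower number from compound 2 to compound 3 (0.10 log units; within the scatter), so isobutylamino and butylamino on this carbonyl carbon cannot be told apart. The other comparison, no change at the digits printed from compound 1 to compound 3 (within the scatter), also stays within the scatter, so at this position neither branching nor isobutylamino in place of butoxy registers as a difference. Nothing available gives a reason for this flat result.

Still open, as far as these compounds go, is whether a carboxylic acid, an amine, a benzyl group or a much longer chain on this carbonyl carbon would move the number beyond the scatter.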